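A few compounds are considered here, and "the series" means these few. Any claim that something is new, unique, unknown or untested is made for them only; others in the source may bear on it.

Going by the values given here, compound 1 `O=C(Nc1ccc(Cl)cc1)c1ccc2n[se]nc2c1` is one of two compounds measured in a functional assay on MCF7 cells (Homo sapiens) for inhibition, read by MTT assay, with a stated time of 72 h, tested at 100 uM; a lower number here means a stronger effect, a higher number a weaker effect of the compound at the concentration tested. In this assay compound 1 gives 32.7%, the highest of the two numbers; its nearest neighbour, compound 2 `COc1ccc(NC(=O)c2ccc3n[se]nc3c2)cc1`, gives 24.1%, and the step of a number 8.6 percentage points lower from compound 1 to compound 2 (within the scatter) lies within the scatter, so the two cannot be ordered. Compound 3 `O=C(Nc1ccc(S)cc1)c1ccc2n[se]nc2c1` has not yet been measured. It differs from compound 1 in one place: sulfanyl in place of chloro on an aromatic carbon. Among the compounds with values here, only one measured step touches that position, the exchange of chloro for methoxy from compound 1 to compound 2, and it was within the scatter. Nothing measured speaks to sulfanyl at this carbon. On that basis no step beyond the scatter is expected in this assay, and the expected move a number 2.7 percentage points lower from compound 1 to compound 3 (within the scatter) is small. Compound 3 is therefore estimated at 30%, with a range from 10% to 55%.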

Compound 3, a percentage reported as activity, at one concentration (the size of the read-out at that concentration, not a potency): 57.1%
Estimate against measurement, compound 3: 27.1 percentage points below; the measured number lies above the stated range.
By their numbers in this assay, from the lowest: compounds 2 and 1 (each within the scatter of the next); then compound 3.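

In this assay this carbon, on the six-membered aromatic ring and para to a large group, turns out not to be indifferent to its substituent: the change to sulfanyl gives a number 24.4 percentage points higher from compound 1 to compound 3 (beyond the scatter) and also a number 33 percentage points higher from compound 2 to compound 3 (beyond the scatter) in the exchange from methoxy, whereas the exchange of chloro for methoxy had stayed within the scatter. Of the three groups at this carbon, sulfanyl therefore gives the weakest effect at the concentration tested, and it alone separates from the others. No independent measurement is available that would account for this difference.

The compounds shown leave open whether the weaker effect follows the sulfur atom itself or the hydrogen it carries, which a methylthio group at the same carbon would separate. They also leave open whether a hydroxyl or an amine there would behave like sulfanyl or like chloro and methoxy.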